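From methylcarbamoyl to carboxy on the shared core

The source may hold more compounds than are shown below. What is called first, only, known or untested is meant among the compounds shown, and "the series" means these compounds.

Values so far, both of them limits, from a functional assay on KB cells (Homo sapiens) for inhibition, read by sulforhodamine B assay, with a stated time of 72 h; on this read-out higher numbers stand for weaker inhibition of growth and lower numbers for stronger inhibition of growth
Compound 1 `NNC(=O)CCc1ccncc1-c1ccc2ccccc2c1` gives the limit > 10000 nM
Compound 2 `CNC(=O)CCc1ccncc1-c1ccc2ccccc2c1` gives the limit > 10000 nM

In this assay compound 2 shows only a limit (> 10000 nM) and no measured number. Compound 3 `O=C(O)CCc1ccncc1-c1ccc2ccccc2c1` keeps the shared core and carries hydroxy in place of methylamino on a carbonyl carbon, so that methylcarbamoyl becomes carboxy. Going by the values given here, the one measured step at this carbonyl group is a step that the two limits leave unreadable from compound 1 to compound 2 and so offers no size to carry over. No step beyond the usual scatter is expected in this assay because of the limit of > 10000 nM in this assay, at which 2 of the 2 values shown sit, and a limit is the likely report for compound 3 as well. Taken from a limit, the estimated step that the limit leaves unreadable from compound 2 to compound 3 is only a rough figure. Compound 3 is expected to lie near 15000 nM (estimated range 6000 nM to 40000 nM).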

Compound 3, concentration for 50% growth inhibition: > 10000 nM
Compound 3 gave a limit, no number; the forecaster's own chance of this, stated with the estimate: 90%; the middle value does not contradict the limit.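

Compound 1, compound 2 and compound 3 all give limits rather than measured numbers, so no step among them can be read: the limit of > 10000 nM in this assay, at which 3 of the 3 values shown sit.

The compounds shown leave open how strongly any of the three inhibits growth, and whether the group on the carbonyl carbon makes any difference to that.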